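This account rests on a few compounds, and the source may have more. Where it says the series, first, only, none or still open, it means among the compounds named here.

Measured in a functional assay on K562 cells (Homo sapiens) for cytotoxicity, read by MTT assay, with a stated time of 48 h (on this read-out higher numbers stand for weaker inhibition and lower numbers for stronger inhibition), so far:
compound 1 `CC[C@H](C)[C@H](NC(=O)[C@@H](NC(=O)OC(C)(C)C)C(C)C)C(=O)N1Cc2cc(OCC(=O)NO)ccc2C[C@H]1C(=O)Nc1ccc(OC)cc1` gives 2780 nM
compound 2 `CC[C@H](C)[C@@H](CN1Cc2cc(OCC(=O)NO)ccc2C[C@H]1C(=O)Nc1ccc(OC)cc1)NC(=O)OC(C)(C)C` gives 7000 nM

Compound 2 at 7000 nM has the higher of the two numbers and is the weaker of this pair. The gap down to compound 1 at 2780 nM lies beyond the scatter. These two compounds differ in more than one place, so the gap is not read as the result of any single change.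

Compound 3 `CC[C@H](C)[C@@H](CN1Cc2cc(OCC(=O)NO)ccc2C[C@H]1C(=O)Nc1ccc(OC)cc1)NC(=O)CC(C)(C)C` awaits measurement. Its difference from compound 2 is neopentyl in place of tert-butoxy on a carbonyl carbon and in words this is neopentyl in place of tert-butoxy on a carbonyl carbon, or tert-butoxycarbonyl to neopentylcarbonyl. For the measured compounds named here, no measured pair shows this exchange, so the expectation rests on compound 2 at 7000 nM as the starting point. In this assay the estimated 1.1-fold lower number from compound 2 to compound 3 (0.03 log units; within the scatter) is expected to stay within the scatter, with no direction favoured. For compound 3 the expected value is 6500 nM with an estimated range from 2300 nM to 18000 nM as the working figure.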

Compound 3, half-maximal inhibitory concentration: 10000 nM
Estimate against measurement, compound 3: 1.5-fold (0.19 log units) below, within the range that was stated.
By their numbers in this assay, from the lowest: compound 1; then compounds 2 and 3 (each within the scatter of the next).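

In this assay, exchanging tert-butoxycarbonyl for neopentylcarbonyl gives a 1.4-fold higher number from compound 2 to compound 3 (0.15 log units; within the scatter), so compound 2 and compound 3 cannot be told apart on this read-out. For the compounds shown here, this is the first single-place comparison, and it shows that tert-butoxycarbonyl and neopentylcarbonyl, both with the same count of 5 heavy atoms in the exchanged group, read alike here even though the oxygen of tert-butoxy, with its 1 hydrogen-bond acceptor, is absent from neopentyl, which has 0. No measurement is available that would account for this result.

The two groups compared are uncharged, ring-free and equal in heavy-atom count, so the compounds shown leave open how this place responds to an amine, a carboxylic acid, a phenyl ring or a longer alkyl chain. As far as these compounds go, it also remains open whether the same exchange reads the same way on the core of compound 1, which differs from compound 2 in more than one place.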